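This account rests on a few compounds, and the source may have more. Where it says the series, first, only, none or still open, it means among the compounds named here.

The measured compounds, all sharing one core:

- compound 1, `CCCCCCCCCCCCCCNC(=O)[C@@H](NC(=O)c1ccco1)[C@@H](C)O`: > 400000 nM
- compound 2, `CCCCCCCCCCCCCCNC(=O)[C@@H](NC(=O)c1cc2ccccc2o1)[C@@H](C)O`: 23400 nM
- compound 3, `CCCCCCCCCCCCCCNC(=O)[C@@H](NC(=O)/C=C/c1ccccc1)[C@@H](C)O`: 150000 nM

In a functional assay on HepG2 cells (Homo sapiens) for cytotoxicity, read by MTT assay, with a stated time of 48 h (a lower number here means a stronger inhibitor, a higher number a weaker inhibitor), compound 1 gives only a limit, > 400000 nM, and not a number; (the limit of > 400000 nM in this assay, at which 1 of the 3 values shown sits). Compound 2 gives 23400 nM in this assay, and compound 3 gives 150000 nM. Among the two numbers shown, compound 3 sits highest; the nearest is compound 2, and the step of a 6.4-fold higher number from compound 2 to compound 3 (0.81 log units; beyond the scatter). The other measured steps, an at least 17-fold lower number from compound 1 to compound 2 (1.23 log units; beyond the scatter) and an at least 2.6-fold lower number from compound 1 to compound 3 (0.42 log units; beyond the scatter), start from a limit, so their true size is open.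

Compound 4, `CCCCCCCCCCCCCCNC(=O)[C@@H](NS(=O)(=O)c1ccc(C)cc1)[C@@H](C)O`, is not yet measured. It differs from compound 3 in that ((4-methylphenyl)sulfonyl in place of (2-phenylethenyl)carbonyl on an amine nitrogen). Going by the values given here, none of the measured steps changes the carbonyl itself for a sulfonyl; all three exchange one group on a carbonyl carbon, so they bear only loosely on this step, showing that the identity of the group on the amine nitrogen moves this assay over a wide span.

Compound 4 is therefore expected to give about 120000 nM in this assay, within 30000 nM to 400000 nM, and the expected step of a 1.3-fold lower number from compound 3 to compound 4 (0.10 log units; within the scatter) is taken to be small against that uncertainty.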

Compound 4, half-maximal inhibitory concentration: 10900 nM
Estimate against measurement, compound 4: 11-fold (1.04 log units) above; measured number outside the range, below it.
By their numbers in this assay, from the lowest: compound 4; then compound 2; then compound 3. At a limit, above all of these: compound 1.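

In this assay, the exchange of (2-phenylethenyl)carbonyl for (4-methylphenyl)sulfonyl on this amine nitrogen shows that a large move does not need a different group on a carbonyl carbon: a 14-fold lower number from compound 3 to compound 4 (1.14 log units; beyond the scatter), although both groups count the same heavy atoms and hold one six-membered aromatic ring. The sulfonyl compound also passes the best of the carbonyl compounds, with a 2.1-fold lower number from compound 2 to compound 4 (0.33 log units; beyond the scatter), so the lowest number of the series no longer belongs to a carbonyl compound. The widest step shown, an at least 36-fold lower number from compound 1 to compound 4 (1.56 log units; beyond the scatter), starts from a limit, so its true size stays open: the limit of > 400000 nM in this assay, at which 1 of the 4 values shown sits.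

The sulfonyl and the 4-methylphenyl group change together in every step to compound 4, and no pair here keeps one while changing the other, so the compounds shown cannot say which of the two carries the step. On these data alone, whether a plain methyl or a 4-chlorophenyl on the sulfonyl, or a benzoyl on the same amine nitrogen, would give a number in this range also stays open.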